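Swapping an Amide for a Sulfonamide on a Shared Core

The source may report more compounds than this note shows. Statements on the series, on what has been measured and on what is new or still open speak of the compounds shown alone.

Compound 1, `CN(C(=O)C(C)(C)C)c1ccc2[nH]c(-c3n[nH]c4ccccc34)cc2n1`: 8390 nM
Compound 2, `CN(C(=O)c1ccc(Cl)cc1)c1ccc2[nH]c(-c3n[nH]c4ccccc34)cc2n1`: 630 nM
Compound 3, `COc1ccc(C(=O)N(C)c2ccc3[nH]c(-c4n[nH]c5ccccc45)cc3n2)cc1`: 12900 nM

All three share one core and differ only in the group attached to the methyl-bearing nitrogen. In a functional assay on KB cells (Homo sapiens) for antiproliferative activity, read by MTT assay, with a stated time of 72 h (a higher number here means a weaker inhibitor, a lower number a stronger inhibitor), compound 3 stands highest of the three numbers; the step of a 1.5-fold higher number from compound 1 to compound 3 (0.19 log units; within the scatter) lies within the scatter, whereas a 20-fold higher number from compound 2 to compound 3 (1.31 log units; beyond the scatter) is large. Compound 4, `CN(c1ccc2[nH]c(-c3n[nH]c4ccccc34)cc2n1)S(=O)(=O)c1ccccc1`, brings the change (phenylsulfonyl in place of (4-methoxyphenyl)carbonyl on a nitrogen on an aromatic ring). Among the compounds with values here, no measured step exchanges a carbonyl for a sulfonyl, so the nearest guides are a 20-fold higher number from compound 2 to compound 3 (1.31 log units; beyond the scatter) and a 13-fold lower number from compound 1 to compound 2 (1.12 log units; beyond the scatter), which show that the group on this nitrogen can move the number strongly. Losing the methoxy that made compound 3 weak is expected to lower the number, though the untested linker widens the range. Compound 4 is expected at 3000 nM (range 500 nM to 20000 nM), a step of a 4.3-fold lower number from compound 3 to compound 4 (0.63 log units; beyond the scatter).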

Compound 4, half-maximal inhibitory concentration: 2400 nM
Estimate against measurement, compound 4: 1.3-fold (0.10 log units) above; measured number inside the range.
By their numbers in this assay, from the lowest: compound 2; then compound 4; then compounds 1 and 3 (each within the scatter of the next).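

Measured in this assay the phenylsulfonyl group on this nitrogen falls within the span of the amides: there is a 5.4-fold lower number from compound 3 to compound 4 (0.73 log units; beyond the scatter) and a 3.5-fold lower number from compound 1 to compound 4 (0.54 log units; beyond the scatter) but also a 3.8-fold higher number from compound 2 to compound 4 (0.58 log units; beyond the scatter) so a carbonyl is not required here, yet compound 4 does not match compound 2. No measurement shown gives a reason for these steps. Compound 4 changes the linker and drops the ring substituent together, so the two effects cannot be separated. The compounds shown leave open how an unsubstituted benzoyl amide or a 4-chlorophenylsulfonyl group would compare.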